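The compounds below may be only part of what the source reports. "The series", "measured", "known", "first", "only" and "open" are said of these compounds alone.

In a functional assay on HCT-116 cells (Homo sapiens) for inhibition (on this read-out lower numbers stand for stronger inhibition and higher numbers for weaker inhibition), compound 1 `COCCOc1cc(/C=C/c2ccc3ccccc3c2)ccc1OC` reaches only a limit, > 5000 nM. Among the compounds with values here, compound 2 `COCCOc1cc(/C=C\c2ccc3ccccc3c2)ccc1OC` gives 2990 nM, the one actual number so far. Within the data shown here, the single measured step, an at least 1.6-fold lower number from compound 1 to compound 2 (0.22 log units; that floor lies within the scatter), concerns only the fact that compounds 1 and 2 differ only in the configuration as drawn and leaves the substituent now in question untouched, so it sets no size for the next change. Compound 3 `COc1ccc(/C=C\c2ccc3ccccc3c2)cc1N` keeps the Z double bond and carries amino in place of 2-methoxyethoxy on an aromatic carbon, amino in place of 2-methoxyethoxy on an aromatic carbon. Among the measured compounds shown here, no measured step covers this change, so a lower number is expected only tentatively, as the estimated 6.0-fold lower number from compound 2 to compound 3 (0.78 log units; beyond the scatter). For compound 3 the expected value is 500 nM, within an estimated range of 60 nM to 4000 nM.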

Compound 3, half-maximal inhibitory concentration: 360 nM
Compound 3: middle estimate off by 1.4-fold (0.14 log units), on the high side; the measured number falls inside the stated range.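

In this assay, within the data shown here, this position, ortho to a methoxy group, proves sensitive to its substituent: amino in place of 2-methoxyethoxy gives an 8.3-fold lower number from compound 2 to compound 3 (0.92 log units; beyond the scatter) in the first step that is clearly beyond the scatter. The earlier step left this position untouched, so it gave no such reading: the fact that compounds 1 and 2 differ only in the configuration as drawn.

One pair cannot separate the entry of amino from the departure of the longer chain. As far as these compounds go, whether a hydroxyl or a dimethylamino group at this position would give a similar number remains open.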